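A few compounds are considered here, and "the series" means these few. Any claim that something is new, unique, unknown or untested is made for them only; others in the source may bear on it.

Three compounds have been measured in an assay on isolated protein for displacement of a labelled ligand from melanin-concentrating hormone receptor 1 (Homo sapiens); on this read-out lower numbers stand for stronger inhibition and higher numbers for weaker inhibition:

Compound 1 `CCCc1cc(N)c2cc(NC(=O)/C=C/c3ccc(C(C)(C)C)cc3)ccc2n1`: 22 nM
Compound 2 `CCCc1cc(N2CCCCC2)c2cc(NC(=O)/C=C/c3ccc(C(F)(F)F)cc3)ccc2n1`: > 4000 nM
Compound 3 `CCCc1cc(N)c2cc(NC(=O)C3CCC(c4ccc(Cl)cc4)CC3)ccc2n1`: 4.4 nM

The value for compound 2 is a limit of this assay and not a number, (the limit of > 4000 nM in this assay, at which 1 of the 3 values shown sits). Among the two numbers that remain, compound 1 stands highest, and compound 3 gives the lower number, a gap that lies beyond the usual scatter of repeated measurements.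

Compound 4 `CCCc1cc(N)c2cc(NC(=O)/C=C/c3ccc(I)cc3)ccc2n1` has not yet been measured. It differs from compound 1 in one place: iodo in place of tert-butyl on an aromatic carbon. The rest of the shared core, including the propyl group and the amino group, is unchanged, and the amide with its double bond is kept.

Going by the values given here, no step between measured compounds matches this change, so there is nothing to anchor it directly. Both groups sit at the same aromatic carbon, and the tert-butyl is replaced by a single iodine atom. The expected step from compound 1 to compound 4 is a 1.4-fold higher number from compound 1 to compound 4 (0.13 log units; within the scatter), which is small enough that it may fall within the scatter. Compound 4 is therefore expected to give about 30 nM in this assay, with a range from 8 nM to 120 nM.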

Compound 4, half-maximal inhibitory concentration: 2.3 nM
For compound 4 the middle estimate is 13-fold (1.12 log units) above the measured one; measured number below the stated range.
By their numbers in this assay, from the lowest: compounds 4 and 3 (each within the scatter of the next); then compound 1. At a limit, above all of these: compound 2.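

In this assay, iodo in place of tert-butyl on the aromatic carbon gives a 9.6-fold lower number from compound 1 to compound 4 (0.98 log units; beyond the scatter) and so stronger inhibition. This is the first step shown at this position, and it shows that the number responds clearly to the group placed there. It also shows that four carbon atoms are not needed at this carbon, since one iodine atom gives the lower number, but nothing measured here explains why.

Still open, as far as these compounds go, is whether another single atom, such as bromine or chlorine, would give a number close to that of compound 4. From the compounds shown here alone, it is equally open how a methoxy group, a longer chain, an amine or a carboxylic acid on this same carbon would behave.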